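Replacing Cyclohexylamino with Methylpiperazine in an Aromatase Series

The source may hold more compounds than are shown below. What is called first, only, known or untested is meant among the compounds shown, and "the series" means these compounds.

Measured so far:
compound 1 `N#Cc1ccc(Oc2cccnc2)cc1NC1CCCCC1`: 33%
compound 2 `COc1ccc(Oc2cc(Oc3cccnc3)ccc2C#N)cc1`: 84%
compound 3 `Cc1cc(-n2ccc3ccncc32)ccc1Cl`: 96%

In an assay on isolated protein for inhibition of Aromatase (Homo sapiens), read by fluorescence, tested at 1 uM (a higher number here means more inhibition at the concentration tested (going by the name of the read-out), a lower number less inhibition), compound 1 gives the lowest of the three numbers. Compound 2 and compound 3 both lie above it, and both gaps are beyond the usual scatter, so the number of compound 1 in this assay is clearly the lowest of the measured set. Compound 4 `CN1CCN(c2cc(Oc3cccnc3)ccc2C#N)CC1` has not yet been measured. It differs from compound 1 in a single place: 4-methylpiperazin-1-yl in place of cyclohexylamino on an aromatic carbon. Within the data shown here, no measured pair shows this change, so its step cannot be read from the data. A small upward step is expected, though one lost in the scatter would not be surprising. The step of a number 12 percentage points higher from compound 1 to compound 4 (beyond the scatter) is expected to be modest. Compound 4 is expected to give 45%, with a range from 20% to 75%.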

Compound 4, a percentage reported as inhibition, at one concentration (the size of the read-out at that concentration, not a potency): 8%
Beside the measured number, compound 4's estimate is 37 percentage points above it; measured number below the stated range.
By their numbers in this assay, from the lowest: compound 4; then compound 1; then compound 2; then compound 3.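

In this assay, placing 4-methylpiperazin-1-yl instead of cyclohexylamino on the aromatic carbon ortho to the cyano group gives a number 25 percentage points lower from compound 1 to compound 4 (beyond the scatter). Among these compounds, this is the first step read at this position, and it shows that the number here depends on which six-membered ring is attached, even though both groups have the same heavy-atom count. No available evidence explains the drop.

The change swaps the ring's atoms and removes the hydrogen-bond donor together, so the compounds shown cannot separate these two differences. From the compounds shown here alone, how a piperidin-1-yl group or a morpholin-4-yl group would read at this position remains open.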